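Replacing 1,3-benzothiazol-2-yl in compound 2

A few compounds are considered here, and "the series" means these few. Any claim that something is new, unique, unknown or untested is made for them only; others in the source may bear on it.

In a functional assay on K562 cells (Homo sapiens) for antiproliferative activity, read by MTT assay, with a stated time of 48 h (a higher number here means a weaker inhibitor, a lower number a stronger inhibitor), compound 1 (`CN(C)CCn1c(N)c(-c2nc3ccccc3s2)c2nc(C#N)c(C#N)nc21`) gives 8000 nM and compound 2 (`CN(C)CCCn1c(N)c(-c2nc3ccccc3s2)c2nc(C#N)c(C#N)nc21`) gives 1800 nM, the lower of the two numbers. Going by the values given here, the only measured step, a 4.4-fold lower number from compound 1 to compound 2 (0.65 log units; beyond the scatter), lies on the chain, with (dimethylamino)methyl in place of dimethylamino. Compound 3 (`CN(C)CCCn1c(N)c(-c2nc3cc(Cl)ccc3[nH]2)c2nc(C#N)c(C#N)nc21`) keeps the 3-(dimethylamino)propyl group and differs elsewhere: 5-chloro-1H-benzimidazol-2-yl in place of 1,3-benzothiazol-2-yl on an aromatic carbon, next to the ring atom that bears an amino group (5-chloro-1H-benzimidazol-2-yl in place of 1,3-benzothiazol-2-yl on an aromatic carbon). Among the compounds with values here, no measured step covers a change at this place, so the chain step offers only a rough scale for one change, and the direction remains open. The expected step is small and not clearly beyond the scatter: a 1.4-fold lower number from compound 2 to compound 3 (0.14 log units; within the scatter). For compound 3 the estimated value is 1300 nM, with an expected range of 350 nM to 4500 nM.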

Compound 3, half-maximal inhibitory concentration: 10700 nM
Estimate against measurement, compound 3: 8.2-fold (0.92 log units) below; the measured number lies above the stated range.
By their numbers in this assay, from the lowest: compound 2; then compounds 1 and 3 (each within the scatter of the next).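

In this assay, going by these compounds alone, the first measured change at this place, on the aromatic carbon next to the ring atom that bears an amino group, shows that the position is not indifferent to its group: 5-chloro-1H-benzimidazol-2-yl in place of 1,3-benzothiazol-2-yl gives a 5.9-fold higher number from compound 2 to compound 3 (0.77 log units; beyond the scatter). This single swap changes several things at once, since sulfur leaves, chlorine enters, and the group goes from 0 to 1 hydrogen-bond donors, so the step cannot be assigned to any one of them. Nothing at hand explains the step. Unsubstituted 1H-benzimidazol-2-yl would separate the chlorine from the ring change, and where it falls relative to compound 2 and compound 3 remains open. Also open, on these data alone, is whether a longer chain, such as 4-(dimethylamino)butyl, would extend the chain step.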